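The source may hold more compounds than are shown below. What is called first, only, known or untested is meant among the compounds shown, and "the series" means these compounds.

Measured in an assay for inhibition of Polyunsaturated fatty acid 5-lipoxygenase (Homo sapiens), read by spectrophotometry, tested at 20 uM; on this read-out lower numbers stand for less inhibition and higher numbers for more inhibition at the one concentration tested (going by the name of the read-out):
- compound 1, `O=C(/C=C/C=C/c1ccc(Cl)cc1)N1CCCCC1`: 14.5%
- compound 2, `COc1ccc(/C=C/C=C/C(=O)N2CCCCC2)cc1OC`: 51.9%

Compound 1 stands lowest of the two numbers in this assay; its nearest neighbour is compound 2, which reads higher by a margin beyond the usual scatter. Within the data shown here, the two compounds differ in more than one place, so no single step between them is counted; their two values show only that compound 2 inhibits more than compound 1 at the concentration tested.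

The step now followed goes from compound 1 to compound 3, `O=C(/C=C/C=C/c1ccc(F)cc1)N1CCCCC1`. The change is a single-atom swap: fluoro in place of chloro on an aromatic carbon. The group that leaves and the group that enters each count one heavy atom, carry no ring, no hydrogen-bond donors or acceptors and no net charge; the place is an aromatic carbon of a six-membered aromatic ring of carbon only, para to a large group.

Among the measured compounds shown here, no measured pair in this set differs in one place, so there is no counted step to lean on. The expected step in this assay is small and not beyond the scatter, if anything a little downward; compound 1 already reads 14.5%, leaving little room below. The expected step is a number 2.5 percentage points lower from compound 1 to compound 3 (within the scatter). Compound 3 is expected to give about 12%, within 0% to 28%.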

Compound 3, a percentage reported as inhibition, at one concentration (the size of the read-out at that concentration, not a potency): 48.7%
Beside the measured number, compound 3's estimate is 36.7 percentage points below it; the measured number lies above the stated range.
By their numbers in this assay, from the lowest: compound 1; then compounds 3 and 2 (each within the scatter of the next).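

In this assay, among these compounds, fluoro in place of chloro on an aromatic carbon, para to a large group, gives a number 34.2 percentage points higher from compound 1 to compound 3 (beyond the scatter), the first step that can be read at a single place. This position is therefore not indifferent to the identity of its substituent: the group that leaves and the group that enters each count one heavy atom, with no ring, no hydrogen-bond donors or acceptors and no net charge, so none of these counted features separates compound 1 from compound 3. No measurement available here explains why this single-atom swap moves the read-out.

As far as these compounds go, it remains open whether the step belongs to fluoro specifically or to the loss of chloro, and a bromo group, a trifluoromethyl group or a bare hydrogen on the same aromatic carbon of the core of compound 1 would help separate those readings. Each number is also a read-out at one concentration, so how the step would carry over to potency stays unresolved, as does whether it would recur with an amide other than the piperidine-bearing one shown here.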